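A few compounds are considered here, and "the series" means these few. Any claim that something is new, unique, unknown or untested is made for them only; others in the source may bear on it.

Three hydrazones on the shared core of compound 1 `O=C(N/N=C/c1ccccc1Cl)c1cnccn1` have been measured in an ADME assay on J774 cells (Mus musculus) for cytotoxicity, read by MTT assay, with a stated time of 48 h, tested at 150 ug/mL; a lower number here means a stronger effect, a higher number a weaker effect of the compound at the concentration tested. Compound 1 gives 69%. Compound 2 `O=C(N/N=C/c1cccc(Cl)c1)c1cnccn1` gives 100%. Compound 3 `O=C(N/N=C/c1ccc(Cl)cc1)c1cnccn1` gives 56%, the lowest of the three numbers; its nearest neighbour is compound 1, whose number is higher by a gap beyond the scatter, and its furthest is compound 2, whose number is higher by a larger gap that is also beyond the scatter. The three chlorine positions therefore give numbers that separate, with compound 3 at the low end.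

Compound 4 `O=C(N/N=C/c1ccc(O)cc1)c1cnccn1` has not been measured. It differs from compound 3 by hydroxy in place of chloro on an aromatic carbon. Within the data shown here, no measured pair in the set shows this change, so the size of the step has no precedent here. The expectation is a modest rise from compound 3 to compound 4 in this assay, a step of a number 14 percentage points higher from compound 3 to compound 4 (beyond the scatter), with the direction more certain than the size. Compound 4 is accordingly expected to give about 70% in this assay, within a range of 45% to 100%.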

Compound 4, a percentage reported as activity, at one concentration (the size of the read-out at that concentration, not a potency): 80%
The estimate for compound 4 lay 10 percentage points below the measured number, and the stated range covers the measured number.
By their numbers in this assay, from the lowest: compound 3; then compound 1; then compound 4; then compound 2.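

Hydroxy in place of chloro on an aromatic carbon, para to a large group, gives a number 24 percentage points higher from compound 3 to compound 4 (beyond the scatter) in this assay. The earlier compounds shown here varied only where the chlorine sat, whereas this pair holds the place fixed and changes the group, showing that the number at this place depends on the group carried there as well as on the position. Nothing available explains the size or direction of this step.

The compounds shown leave open whether an amine or a carboxylic acid at this same place would give a number nearer that of compound 3 or that of compound 4. They also leave open whether hydroxy would give a similar step at the places held by chlorine in compound 1 and compound 2.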